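A few compounds are considered here, and "the series" means these few. Any claim that something is new, unique, unknown or untested is made for them only; others in the source may bear on it.

Within the data shown here, compound 1 `CNC(=O)c1cc(Oc2ccc3nc(NC(=O)c4ccc(Cl)cc4Cl)sc3c2)ccn1` gives 15.1% in a functional assay on HCT-116 cells (Homo sapiens) for inhibition, read by MTT assay, with a stated time of 2 days, tested at 10 uM (a lower number here means less inhibition of growth, a higher number more inhibition of growth at the concentration tested), the lowest of the three numbers measured so far. Compound 2 `CNC(=O)c1cc(Oc2ccc3nc(NC(=O)c4ccc(Cl)cc4)sc3c2)ccn1` gives 27.5%, and compound 3 `CNC(=O)c1cc(Oc2ccc3nc(NC(=O)Nc4ccc(N5CCN(C)CC5)cc4)sc3c2)ccn1` gives 24.6%, a value within the scatter of that of compound 1. Compound 4 `CNC(=O)c1cc(Oc2ccc3nc(NC(=O)Nc4ccc(F)cc4)sc3c2)ccn1` differs from compound 1 in one place: (4-fluorophenyl)amino in place of 2,4-dichlorophenyl on a carbonyl carbon. The 2,4-dichlorophenyl group leaves and a (4-fluorophenyl)amino group enters on the carbonyl carbon. Among the measured compounds shown here, one measured step bears on this change: a number 12.4 percentage points higher from compound 1 to compound 2 (beyond the scatter). Compound 3, the closest structural relative of compound 4 among the measured compounds, gives a number indistinguishable from that of compound 1. A modest rise is therefore expected, a number 9.9 percentage points higher from compound 1 to compound 4 (within the scatter). Compound 4 is estimated at 25%, with a range from 10% to 40%.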

Compound 4, percent growth inhibition at one concentration: 12.2%
For compound 4 the middle estimate is 12.8 percentage points above the measured one; low and high end bracket the measured number.
By their numbers in this assay, from the lowest: compounds 4, 1, 3 and 2 (each within the scatter of the next, the first and the last beyond it).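

In this assay, (4-fluorophenyl)amino in place of 2,4-dichlorophenyl on the carbonyl carbon gives a step that cannot be told from scatter, a number 2.9 percentage points lower from compound 1 to compound 4 (within the scatter), so this exchange leaves the reading effectively unchanged. Fluoro in place of 4-methylpiperazin-1-yl gives a number 12.4 percentage points lower from compound 3 to compound 4 (beyond the scatter), and (4-fluorophenyl)amino in place of 4-chlorophenyl gives a number 15.3 percentage points lower from compound 2 to compound 4 (beyond the scatter), so the amino link on the carbonyl carbon does not by itself secure a higher number. No available evidence explains these steps. Still open, on these data alone, is whether a morpholin-4-yl group or a methoxy group in place of fluoro would move the number.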